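The compounds below may be only part of what the source reports. "The series", "measured", "known", "first", "only" and "open" are said of these compounds alone.

Three compounds have been measured in a functional assay on A-375 cells (Homo sapiens) for antiproliferative activity, read by CCK-8 assay, with a stated time of 72 h, tested at 8 uM; on this read-out higher numbers stand for a stronger effect at the one concentration tested and lower numbers for a weaker effect:

compound 1 `CC1CCN(C(=S)SCc2ccc(C(=O)Nc3ccccc3N)cc2)CC1` gives 87.4%
compound 2 `Nc1ccccc1NC(=O)c1ccc(CSC(=S)N2CCN(Cc3ccncc3)CC2)cc1` gives 89.5%
compound 3 `Nc1ccccc1NC(=O)c1ccc(CSC(=S)N2CCc3cc(Cl)ccc32)cc1` gives 82.3%

Among these three, the number of compound 2 is the highest, yet the gaps to compound 1 and to compound 3 are both within the usual scatter of repeated measurements, so the three compounds cannot be told apart on this read-out. Among the compounds with values here, the only pair that differs in one place is compound 1 and compound 3, where the change sits on the thiocarbonyl carbon and the result is a number 5.1 percentage points lower from compound 1 to compound 3 (within the scatter), a step inside the scatter.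

Compound 4 `Nc1ccccc1NC(=O)c1ccc(CSC(=S)N2CCN(Cc3cccnc3)CC2)cc1` has not yet been measured. It differs from compound 2 in one place: pyridin-3-yl in place of pyridin-4-yl on a saturated chain carbon bound to an amine nitrogen in a ring. Within the data shown here, no measured pair shows a change at this position, so the one recorded step bears on it only indirectly, by showing that a change elsewhere on the shared core left the number unmoved. On that basis no step beyond the scatter is expected from compound 2 to compound 4; the expected step is a number 1.5 percentage points lower from compound 2 to compound 4 (within the scatter). Compound 4 is therefore estimated to give 88%, with a range from 78% to 96%.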

Compound 4, a percentage reported as inhibition, at one concentration (the size of the read-out at that concentration, not a potency): 89.2%
The estimate for compound 4 lay 1.2 percentage points below the measured number; measured number inside the range.
By their numbers in this assay, from the lowest: compounds 3, 1, 4 and 2 (each within the scatter of the next).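

In this assay, the first change recorded at this position, pyridin-3-yl in place of pyridin-4-yl on a saturated chain carbon bound to an amine nitrogen in a ring, gives a number 0.3 percentage points lower from compound 2 to compound 4 (within the scatter). The earlier compounds showed only a change on the thiocarbonyl carbon, so this step adds direct information: on this read-out, the two pyridinyl attachments cannot be told apart, and both of these compounds remain within the scatter of compound 1 and compound 3. Nothing available offers an account of this result in terms of a measured property of either group.

The compounds shown leave open whether a phenyl ring, a morpholine or a carboxylic acid in place of the pyridin-3-yl group, or a longer chain in place of the methyl in (pyridin-3-yl)methyl, would give a step beyond the scatter. They also leave open whether compound 2 and compound 4 would remain indistinguishable at lower concentrations, as a read-out at one concentration gives the size of the effect there and not a potency.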